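The source may hold more compounds than are shown below. What is called first, only, known or untested is meant among the compounds shown, and "the series" means these compounds.

Compound 1 `Cc1oc(=O)oc1COC(=O)N1C[C@@H]2C[C@H]1C(=O)Nc1cccc(c1)C(=O)OCc1oc(=O)oc1COC(=O)C1=C(S2)[C@H](C)[C@@H]2[C@@H]([C@@H](C)O)C(=O)N12` sits at the assay limit > 95% in a physicochemical assay for metabolic stability, read by LC-MS, in phosphate buffer, with a stated time of 3 h, at pH 7.4, tested at 50 uM; on this read-out lower numbers stand for a less stable compound and higher numbers for a more stable compound.
Compound 2 `CCOC(=O)C1=C(S[C@H]2C[C@@H](C(=O)Nc3cccc(C(=O)OCC)c3)N(C(=O)OCc3oc(=O)oc3C)C2)[C@H](C)[C@@H]2[C@@H]([C@@H](C)O)C(=O)N12` sits at the limit > 95% in this assay.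
Compound 3 `CCOC(=O)C1=C(S[C@@H]2CN[C@H](C(=O)Nc3cccc(C(=O)OCC)c3)C2)[C@H](C)[C@@H]2[C@@H]([C@@H](C)O)C(=O)N12` sits at the limit > 95% in this assay.

Compound 4 `C[C@@H](O)[C@H]1C(=O)N2C3=C(S[C@@H]4CN[C@@H](C4)C(=O)Nc4cccc(c4)C(=O)OCc4oc(=O)oc4COC3=O)[C@H](C)[C@H]12` has not yet been measured. From compound 1 it differs by a hydrogen atom in place of a group of 11 heavy atoms (6 carbon, 5 oxygen; one five-membered aromatic ring with 2 hetero atoms), on an amine nitrogen in a ring. The same kind of change turns compound 2 into compound 3, (a hydrogen atom in place of a group of 11 heavy atoms (6 carbon, 5 oxygen; one five-membered aromatic ring with 2 hetero atoms), on an amine nitrogen in a ring); the surroundings differ, as the nitrogen in compound 1 belongs to a five-membered non-aromatic ring that is part of a fused or bridged system of six rings and lies next to the ring atom that bears a fused ring, whereas in compound 2 it lies next to the ring atom that bears a large group. That step gave a step that the two limits leave unreadable from compound 2 to compound 3. How the cores of compound 1 and compound 2 differ is not broken down here. Because (the limit of > 95% in this assay, at which 3 of the 3 values shown sit), the step from compound 1 to compound 4 is expected to be a number no higher from compound 1 to compound 4 (the limit leaves the size open), and compound 4 is estimated at 95%.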

Compound 4, percent of the compound remaining: > 95%
Compound 4: only a limit was reported; the forecaster's own chance of this, stated with the estimate: 0.7%; the middle value sits exactly at the limit.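

No step can be read from compound 1 to compound 4, nor from compound 2 to compound 3, because each value is a limit: the limit of > 95% in this assay, at which 4 of the 4 values shown sit. The compounds shown leave open whether replacing that group with hydrogen changes the result in this assay at all.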